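Pyridin-2-yl replacing 4-fluorophenyl at the methine carbon

The compounds below may be only part of what the source reports. "The series", "measured", "known", "first", "only" and "open" are said of these compounds alone.

The three measured compounds share one core and differ only in the aryl group on the methine carbon. In an assay on isolated protein for inhibition of CAAX prenyl protease 2 (Homo sapiens), with stated times of 60 s and 60 min (on this read-out lower numbers stand for stronger inhibition and higher numbers for weaker inhibition), compound 1 `N#Cc1ccc(C(Nc2ccc(C(=O)O)cc2)c2ccc3cccnc3c2O)cc1` gives 16000 nM, compound 2 `Cc1ccc(C(Nc2ccc(C(=O)O)cc2)c2ccc3cccnc3c2O)cc1` gives 7100 nM, and compound 3 `O=C(O)c1ccc(NC(c2ccc(F)cc2)c2ccc3cccnc3c2O)cc1` gives 8200 nM. Compound 3 sits close to both neighbours: the step of a 1.2-fold higher number from compound 2 to compound 3 (0.06 log units; within the scatter) and the step of a 2.0-fold lower number from compound 1 to compound 3 (0.29 log units; within the scatter) are each within the scatter, and only a 2.3-fold lower number from compound 1 to compound 2 (0.35 log units; beyond the scatter) reaches beyond it, and then just modestly. Substituent swaps on that ring therefore move this assay little.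

Compound 4 `O=C(O)c1ccc(NC(c2ccccn2)c2ccc3cccnc3c2O)cc1` takes a larger step at the same place: pyridin-2-yl in place of 4-fluorophenyl on a saturated chain carbon bound to an aromatic carbon and a nitrogen on an aromatic ring. Among the compounds with values here, none of the measured steps exchanges the whole ring, so they bear on this change only loosely; they show that cyano, methyl and fluoro on that ring all land within a narrow band. On that basis the step of a 1.0-fold lower number from compound 3 to compound 4 (0.01 log units; within the scatter) is expected to stay within the scatter, with no clear direction, though the wider uncertainty of a ring exchange is acknowledged. Compound 4 is accordingly estimated at 8000 nM in this assay, with a range from 3000 nM to 25000 nM.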

Compound 4, half-maximal inhibitory concentration: 38000 nM
Estimate against measurement, compound 4: 4.8-fold (0.68 log units) below; measured number above the stated range.
By their numbers in this assay, from the lowest: compounds 2, 3 and 1 (each within the scatter of the next, the first and the last beyond it); then compound 4.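

Exchanging the whole ring does what the substituent swaps did not: in this assay, the step of a 4.6-fold higher number from compound 3 to compound 4 (0.67 log units; beyond the scatter) lies beyond the scatter, as do a 5.4-fold higher number from compound 2 to compound 4 (0.73 log units; beyond the scatter) and a 2.4-fold higher number from compound 1 to compound 4 (0.38 log units; beyond the scatter), so compound 4 is the weakest inhibitor of the four. The position on the saturated chain carbon therefore does respond to the aryl group placed there, even though cyano, methyl and fluoro on the carbon-only ring left compounds 1, 2 and 3 in a narrow band. Nothing shown here accounts for the rise, which comes with a ring nitrogen that counts as one hydrogen-bond acceptor, where each of the other three rings has a substituent on a ring of carbon only.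

The pyridin-2-yl group differs from those rings in two ways at once, since it brings in the ring nitrogen and carries no substituent, and the compounds shown cannot separate the two. A plain phenyl ring would address the lost substituent, while a pyridine joined through a different ring carbon, or a pyridin-2-yl bearing a methyl or fluoro group, would address the nitrogen.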